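Nitro step from compound 2 in the triazene series

A few compounds are considered here, and "the series" means these few. Any claim that something is new, unique, unknown or untested is made for them only; others in the source may bear on it.

Measured in an ADME assay on MT4 cells (Homo sapiens) for cytotoxicity, read by MTT assay, with a stated time of 96 h; on this read-out lower numbers stand for higher toxicity in this test and higher numbers for lower toxicity in this test:
- compound 1 `Cc1ccc(/N=N/N(C)c2ccccc2)cc1`: 45000 nM
- compound 2 `CN(/N=N/c1ccccc1)c1ccccc1`: 55000 nM
- compound 3 `CN(C)CCCN(/N=N/c1ccccc1)c1cccc(C(F)(F)F)c1`: 14000 nM

Compound 2 shares the top of this small set with compound 1, the two lying within the scatter of each other. Compound 3 stands clearly lower than both.

Compound 4 `CN(/N=N/c1cccc([N+](=O)[O-])c1)c1ccccc1` is the next case: nitro in place of hydrogen on an aromatic carbon. This places nitro in place of hydrogen on an aromatic carbon, meta to a large group.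

Within the data shown here, only one measured step bears on this change, and only loosely. It is a 1.2-fold higher number from compound 1 to compound 2 (0.09 log units; within the scatter), with hydrogen in place of methyl on an aromatic carbon, and it stays within the scatter. Among the measured compounds shown here, no single-place step links compound 3 to the others, and no nitro compound has been measured. A small step is therefore expected in this assay, lower if anything and not beyond the scatter.

The expected step is a 1.6-fold lower number from compound 2 to compound 4 (0.20 log units; within the scatter). For compound 4 the estimate is 35000 nM, with an expected range of 14000 nM to 80000 nM.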

Compound 4, half-maximal cytotoxic concentration: > 100000 nM
Compound 4: a limit, no number; the forecaster's own chance of this, stated with the estimate: 15%; middle value at least 2.8-fold (0.45 log units) from the limit.
By their numbers in this assay, from the lowest: compound 3; then compounds 1 and 2 (each within the scatter of the next). At a limit, above all of these: compound 4.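

In this assay compound 4 gives > 100000 nM, a limit of the assay and not a number. Nitro in place of hydrogen on an aromatic carbon, meta to a large group, is the first change at this position, and it gives an at least 1.8-fold higher number from compound 2 to compound 4 (0.25 log units; that floor lies within the scatter); this is a floor only, so the true size of the step cannot be read, though no lower number comes with the nitro group. Only compound 4 stands at a limit in the set: the limit of > 100000 nM in this assay, at which 1 of the 4 values shown sits.

The compounds shown leave open whether an amine or a carboxylic acid in place of hydrogen at this position would give a number rather than a limit. Also open, on these data alone, is what nitro would do on compound 3, which differs from compound 2 in more than one place.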